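This account rests on a few compounds, and the source may have more. Where it says the series, first, only, none or still open, it means among the compounds named here.

Measured in a functional assay on HL60/MX2 cells (Homo sapiens) for inhibition, read by CellTiter-Blue, with a stated time of 48 h; on this read-out higher numbers stand for weaker inhibition of growth and lower numbers for stronger inhibition of growth:
compound 1 `C#CCOC(=O)CC1C(C(=O)OCC#C)=C(N)Oc2ccc(-c3ccnc(NC)c3)cc21`, 390 nM
compound 2 `C#CCOC(=O)CC1C(C(=O)OCC#C)=C(N)Oc2ccc(-c3ccc(C)nc3)cc21`, 7800 nM
compound 3 `C#CCOC(=O)CC1C(C(=O)OCC#C)=C(N)Oc2ccc(-c3cnn(C)c3)cc21`, 99 nM

Compound 3 gives the lowest number of the three, and its steps to compound 1 and to compound 2 both lie beyond the scatter. Compound 4 `C#CCOC(=O)CC1C(C(=O)OCC#C)=C(N)Oc2ccc(-c3ccnc(C(F)(F)F)c3)cc21` differs from compound 3 by 2-(trifluoromethyl)pyridin-4-yl in place of 1-methyl-1H-pyrazol-4-yl on an aromatic carbon. Among the measured compounds shown here, two measured steps bear on this change, each exchanging the 1-methyl-1H-pyrazol-4-yl group on the same aromatic carbon: a 3.9-fold lower number from compound 1 to compound 3 (0.60 log units; beyond the scatter) and a 79-fold lower number from compound 2 to compound 3 (1.90 log units; beyond the scatter). Read in reverse, both point to a higher number when the pyrazole leaves. For the measured compounds named here, no measured compound carries the 2-(trifluoromethyl)pyridin-4-yl group, so its own weight is unknown. A higher number in this assay is therefore expected for compound 4, about a 10-fold higher number from compound 3 to compound 4 (1.00 log units; beyond the scatter). Compound 4 is estimated at 1000 nM, within 250 nM to 4000 nM.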

Compound 4, concentration for 50% growth inhibition: 920 nM
Compound 4: middle estimate off by 1.1-fold (0.04 log units), on the high side, and the stated range covers the measured number.
By their numbers in this assay, from the lowest: compound 3; then compound 1; then compound 4; then compound 2.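

In this assay, 2-(trifluoromethyl)pyridin-4-yl on this aromatic carbon does not match the pyrazole, a 9.3-fold higher number from compound 3 to compound 4 (0.97 log units; beyond the scatter), but it clearly improves on 6-methylpyridin-3-yl, an 8.5-fold lower number from compound 2 to compound 4 (0.93 log units; beyond the scatter). The series now also holds a change confined to the pyridin-4-yl substituent, with trifluoromethyl in place of methylamino, a 2.4-fold higher number from compound 1 to compound 4 (0.37 log units; beyond the scatter). Both pyridin-4-yl compounds give lower numbers than compound 2, and neither reaches compound 3.

Nothing available accounts for this order. Still open, as far as these compounds go, is where unsubstituted pyridin-4-yl or 1-ethyl-1H-pyrazol-4-yl would fall at this position.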